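A Sulfonamide Swap and Expected Cell Tolerance

A few compounds are considered here, and "the series" means these few. Any claim that something is new, unique, unknown or untested is made for them only; others in the source may bear on it.

Compound 1 `O=S(=O)(CCCCl)N1CCC2(CC1)OOC1(CCCC1)OO2` was tested in a functional assay on Huh-7 cells (Homo sapiens) for cytotoxicity, read by MTT assay, with a stated time of 72 h; a lower number here means that less compound is tolerated, a higher number that more compound is tolerated. In this assay compound 1 reached only the limit of the assay, > 100 ug/mL, and no number was obtained. Compound 2 `COc1ccc(S(=O)(=O)N2CCC3(CC2)OOC2(CCCCCC2)OO3)cc1` shares the sulfonyl group on a ring nitrogen with compound 1. In this assay compound 2 also gave only the limit > 100 ug/mL. Compound 1 therefore stands where every value shown stands, at the limit of > 100 ug/mL in this assay, at which 2 of the 2 values shown sit. Compound 3 `O=S(=O)(c1ccc(Br)cc1F)N1CCC2(CC1)OOC1(CCCC1)OO2` has not yet been measured. It differs from compound 1 in one place: 4-bromo-2-fluorophenyl in place of 3-chloropropyl on a sulfonyl sulfur. Among the measured compounds shown here, no step between measured compounds is known, so the effect of this change can only be expected, and the step of a number no higher from compound 1 to compound 3 (the limit leaves the size open) is expected to be none beyond the scatter, with compound 3 most likely again reported only as a limit. Compound 3 is accordingly estimated at 100 ug/mL, within a range from 50 ug/mL to 200 ug/mL.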

Compound 3, half-maximal cytotoxic concentration: > 100 ug/mL
Compound 3: no number, only a limit; the forecaster's own chance of this, stated with the estimate: 70%; the middle value sits exactly at the limit.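

Among the compounds shown here, compound 1 and compound 3 are both reported only as limits in this assay, so no step between them can be read. The compounds shown leave open where any of them would reach its half-maximal cytotoxic concentration, and so whether 4-bromo-2-fluorophenyl in place of 3-chloropropyl changes tolerance at all.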